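From Fluorine to Hydroxyl on the Aryl Group

The source may report more compounds than this note shows. Statements on the series, on what has been measured and on what is new or still open speak of the compounds shown alone.

Compound 2 `CC1(C)[C@H]2CC[C@]1(C)N(Cc1cn(-c3ccccc3F)nn1)C(=O)C2` gives 40 nM in a functional assay on LoVo cells (Homo sapiens) for inhibition, read by MTT assay, with a stated time of 24 h (on this read-out higher numbers stand for weaker inhibition and lower numbers for stronger inhibition), the lowest number of the three measured compounds, though compound 3 `CC1(C)[C@H]2CC[C@]1(C)N(Cc1cn(-c3ccc(Br)cc3)nn1)C(=O)C2` with 60 nM sits within the scatter of it. Compound 1 `CC1(C)[C@H]2CC[C@]1(C)N(Cc1cn(-c3cccc(C#N)c3)nn1)C(=O)C2` gives 320 nM; an 8.0-fold lower number from compound 1 to compound 2 (0.90 log units; beyond the scatter) and a 5.3-fold lower number from compound 1 to compound 3 (0.73 log units; beyond the scatter) both stand beyond the scatter. Compound 4 `CC1(C)[C@H]2CC[C@]1(C)N(Cc1cn(-c3cccc(O)c3)nn1)C(=O)C2` differs from compound 2 in one place: 3-hydroxyphenyl in place of 2-fluorophenyl on an aromatic nitrogen. The step that bears on this change is an 8.0-fold lower number from compound 1 to compound 2 (0.90 log units; beyond the scatter) read in reverse, since compound 1 carries a 3-cyanophenyl, the nearest measured relative of a 3-hydroxyphenyl. A hydroxyl is not a nitrile, so only part of that shift is expected: a 3.0-fold higher number from compound 2 to compound 4 (0.48 log units; beyond the scatter). Compound 4 is therefore estimated at 120 nM, with a range from 40 nM to 400 nM.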

Compound 4, half-maximal inhibitory concentration: 410 nM
Estimate against measurement, compound 4: 3.4-fold (0.53 log units) below; the whole stated range lies below it.
By their numbers in this assay, from the lowest: compounds 2 and 3 (each within the scatter of the next); then compounds 1 and 4 (each within the scatter of the next).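

Replacing the 2-fluorophenyl with 3-hydroxyphenyl gives a 10-fold higher number from compound 2 to compound 4 (1.01 log units; beyond the scatter), and replacing the 4-bromophenyl gives a 6.8-fold higher number from compound 3 to compound 4 (0.83 log units; beyond the scatter), in this assay. Hydroxy in place of cyano gives only a 1.3-fold higher number from compound 1 to compound 4 (0.11 log units; within the scatter), so the two 3-substituted phenyl groups stay together at the higher numbers, with neither 2-fluorophenyl nor 4-bromophenyl joining them. No measurement here explains this split. Still open, from the compounds shown here alone, is whether the number follows the group itself or its place on the phenyl ring, and where an amine or a carboxylic acid on that ring would fall.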